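The compounds below may be only part of what the source reports. "The series", "measured", "known", "first", "only" and "open" are said of these compounds alone.

Measured so far in an in vitro functional assay on HEK ts201 cells for antagonist activity at Neuronal acetylcholine receptor; alpha3/beta4 (Homo sapiens), read by fluorescence and calcium flux; a higher number here means a weaker inhibitor, a lower number a stronger inhibitor:
Compound 1 `CC1(C)CC(=O)N(c2ccccc2C(=O)OCC2CCCN(CCCc3ccccc3)C2)C1=O`: 5010 nM
Compound 2 `O=C(OCC1CCCNC1)c1ccccc1-c1ccccc1`: 8130 nM
Compound 3 `O=C(CCC1CCCNC1)c1ccccc1-c1ccccc1`: 6610 nM

Compound 1 shows the lowest of the three numbers in this assay, but its gaps to compound 3 and to compound 2 both lie within the usual scatter, so the three compounds cannot be told apart on these data. Compound 4 `O=C(OCC1CCCN(CCCc2ccccc2)C1)c1ccccc1N1C(=O)c2ccccc2C1=O` has not yet been measured. It differs from compound 1 in one place: a group of 11 heavy atoms (8 carbon, 1 nitrogen, 2 oxygen; one five-membered non-aromatic ring with 1 hetero atom, one six-membered aromatic ring of carbon only) in place of a group of 9 heavy atoms (6 carbon, 1 nitrogen, 2 oxygen; one five-membered non-aromatic ring with 1 hetero atom), on an aromatic carbon. Among the measured compounds shown here, no pair of measured compounds separated by a single change is available, so there is no measured step to lean on. The expectation for this assay is therefore a step from compound 1 to compound 4 of a 1.0-fold lower number from compound 1 to compound 4 (0.00 log units; within the scatter), that is, no change beyond the scatter. Compound 4 is estimated at 5000 nM, within a range of 1500 nM to 16000 nM.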

Compound 4, half-maximal inhibitory concentration: 5890 nM
Estimate against measurement, compound 4: 1.2-fold (0.07 log units) below, and the stated range covers the measured number.
By their numbers in this assay, from the lowest: compounds 1, 4, 3 and 2 (each within the scatter of the next).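

Replacing the 3,3-dimethyl-2,5-dioxopyrrolidin-1-yl group with a larger group that adds a six-membered aromatic ring of carbon only gives a 1.2-fold higher number from compound 1 to compound 4 (0.07 log units; within the scatter) in this assay. This position, on an aromatic carbon ortho to a large group, therefore tolerates the added ring without a change that can be told from the scatter. No measurement is available that would explain this outcome.

On these data alone, whether an amine or a carboxylic acid on this same aromatic carbon would move the number beyond the scatter remains open.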